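A thiazole in place of a pyridinyl ether

The compounds below may be only part of what the source reports. "The series", "measured", "known", "first", "only" and "open" are said of these compounds alone.

In a functional assay on PC-3 cells (Homo sapiens), with a stated time of 24 h, tested at 10 uM (on this read-out higher numbers stand for more inhibition at the one concentration tested (going by the name of the read-out) and lower numbers for less inhibition), compound 1 `O=C(Nc1cccc(OCCc2ccccn2)c1)C1CCCN(C(=O)c2cc(C(F)(F)F)cc(C(F)(F)F)c2)C1` gives only a limit of the assay, < 30%. Compound 2 `O=C(Nc1cccc(Cc2ccccc2)c1)C1CCCN(C(=O)c2cc(C(F)(F)F)cc(C(F)(F)F)c2)C1` likewise gives only a limit, < 30%. Among the compounds with values here, the one measured step, a step that the two limits leave unreadable from compound 1 to compound 2, cannot be read because both values sit at the limit of < 30% in this assay, at which 2 of the 2 values shown sit. Compound 3 `Cc1nc(-c2cccc(NC(=O)C3CCCN(C(=O)c4cc(C(F)(F)F)cc(C(F)(F)F)c4)C3)c2)cs1` differs from compound 1 by 2-methyl-1,3-thiazol-4-yl in place of 2-(pyridin-2-yl)ethoxy on an aromatic carbon. Within the data shown here, no measured step speaks to this change; the two known compounds only show that neither rises above the limit. Compound 3 is therefore expected to stay near that limit, with an estimated step that the limit leaves unreadable from compound 1 to compound 3. In this assay compound 3 is estimated at 15%, expected between 0% and 40%.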

Compound 3, a percentage reported as inhibition, at one concentration (the size of the read-out at that concentration, not a potency): 42%
Compound 3: middle estimate off by 27 percentage points, on the low side; measured number outside the range, above it.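

This position, meta to a large group, can change the read-out in this assay: 2-methyl-1,3-thiazol-4-yl in place of 2-(pyridin-2-yl)ethoxy gives a number at least 12 percentage points higher from compound 1 to compound 3 (beyond the scatter) on the same core. The same group in place of benzyl gives a number at least 12 percentage points higher from compound 2 to compound 3 (beyond the scatter) on that core. As far as these compounds go, the true size of both steps stays unknown, because compound 1 and compound 2 stand only at a limit: the limit of < 30% in this assay, at which 2 of the 3 values shown sit.

From the compounds shown here alone, whether the methyl on the thiazole matters stays open. So does how an amine or a carboxylic acid would read at this position.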